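Cytotoxicity notes: compound 2 to compound 3

The source may report more compounds than this note shows. Statements on the series, on what has been measured and on what is new or still open speak of the compounds shown alone.

Compound 2 `C[C@H]1[C@H](NCc2ccsc2)C[C@H]2C[C@@H]1C2(C)C` and compound 1 `C=C(C)c1csc(CN[C@@H]2C[C@H]3C[C@@H]([C@H]2C)C3(C)C)c1` have both been run in an ADME assay on MDCK cells (Canis lupus familiaris) for cytotoxicity, read by microscopy, with a stated time of 48 h; a higher number here means that more compound is tolerated, a lower number that less compound is tolerated. Compound 2 gives 50000 nM, and compound 1 gives 25000 nM; the two numbers lie within the usual scatter of each other, so neither stands apart. Compound 3 `C[C@H]1[C@H](NCc2nccs2)C[C@H]2C[C@@H]1C2(C)C` has not yet been measured in this assay. Its change from compound 2 is 1,3-thiazol-2-yl in place of thiophen-3-yl on a saturated chain carbon bound to an amine nitrogen. For the measured compounds named here, no measured pair shows this change, and no shift beyond the scatter is expected in either direction. Compound 3 is estimated at 50000 nM, within 25000 nM to 100000 nM. The expected step is no change at the digits printed from compound 2 to compound 3 (within the scatter).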

Compound 3, minimum cytotoxic concentration: > 100000 nM
Compound 3 was reported as a limit; the forecaster's own chance of this, stated with the estimate: 10%; middle value at least 2.0-fold (0.30 log units) away from the limit.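

In this assay, for the compounds shown here, the change to 1,3-thiazol-2-yl in place of thiophen-3-yl gives an at least 2.0-fold higher number from compound 2 to compound 3 (0.30 log units; that floor lies within the scatter) on a saturated chain carbon bound to an amine nitrogen, the first one-place comparison. Compound 3 gives > 100000 nM as a limit of the assay and not a number. The step therefore has a floor but no size, and that floor is all this pair can show: the limit of > 100000 nM in this assay, at which 1 of the 3 values shown sits.

From the compounds shown here alone, whether a phenyl or pyridin-2-yl ring at this place would keep compound 3's tolerance remains open.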